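The compounds below may be only part of what the source reports. "The series", "measured", "known", "first", "only" and "open" are said of these compounds alone.

Measured compounds:
- compound 1 `CCCc1nn2c(C(C)c3ccc(CC(C)C)cc3)nnc2s1` — 34%
- compound 2 `CC(C)Cc1ccc(C(C)c2nnc3sc(-c4ccc(Br)cc4)nn23)cc1` — 67%

In a functional assay on the whole organism (strain Wistar albino) for inhibition, with Rattus norvegicus as the target, read by paw edema, with stated times of 30 min and 3 h, at a dose of 20 mg/kg by the oral route (on this read-out lower numbers stand for less inhibition and higher numbers for more inhibition at the one dose given (going by the name of the read-out)), compound 1 gives 34% and compound 2 gives 67%. Going by the values given here, compound 2 stands highest of the two numbers measured so far, with compound 1 as the nearest and lower neighbour. Among the compounds with values here, the only measured step, a number 33 percentage points higher from compound 1 to compound 2 (beyond the scatter), is large and beyond the scatter; it exchanged a propyl for an aryl group at the same aromatic carbon.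

Compound 3 `CC(C)Cc1ccc(C(C)c2nnc3sc(-c4ccc([N+](=O)[O-])cc4Cl)nn23)cc1` is the next candidate. It differs from compound 2 in one place: 2-chloro-4-nitrophenyl in place of 4-bromophenyl on an aromatic carbon. Within the data shown here, the step from compound 1 to compound 2 bears on this only loosely, since compound 3 keeps an aryl group at that carbon and merely changes its substituents; no measured pair compares one aryl with another at this position. The expected step of a number 4 percentage points lower from compound 2 to compound 3 (within the scatter) is therefore small and not beyond the scatter. Compound 3 is estimated at 63%, with a range of 45% to 80%.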

Compound 3, a percentage reported as inhibition, in the whole organism at one dose (the size of the read-out at that dose, not a potency): 69%
Compound 3: the middle estimate sits 6 percentage points below what was measured; the measured number falls inside the stated range.
By their numbers in this assay, from the lowest: compound 1; then compounds 2 and 3 (each within the scatter of the next).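

In this assay, the exchange at this carbon gives a number 2 percentage points higher from compound 2 to compound 3 (within the scatter), so this first comparison of one aryl group with another shows 4-bromophenyl and 2-chloro-4-nitrophenyl reading alike, even though the entering group has 10 heavy atoms against 7 and 2 hydrogen-bond acceptors against 0. The second aryl group also stands clear of propyl, with a number 35 percentage points higher from compound 1 to compound 3 (beyond the scatter), so among these three compounds the large step away from propyl is not confined to 4-bromophenyl. Nothing available explains either step.

Going by these compounds, whether an unsubstituted phenyl, a phenyl carrying an amine or a carboxylic acid, or a chain longer than propyl at this carbon would read with compound 2 and compound 3 or with compound 1 remains open. On these data alone, all three compounds share the rest of the structure, so the effect of changes elsewhere also remains open.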